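The source may hold more compounds than are shown below. What is called first, only, known or untested is meant among the compounds shown, and "the series" means these compounds.

Compounds measured in an assay on Prostate gland for inhibition of steroid 5-alpha-reductase (Rattus norvegicus); on this read-out higher numbers stand for weaker inhibition and lower numbers for stronger inhibition:
- Compound 1, `CCCCC(CCCC)n1ccc2cc(/C(C)=C/C(=O)Nc3ccccc3OCCCC(=O)O)ccc21`: 21 nM
- Compound 2, `C/C(=C\C(=O)Nc1ccccc1OCCCC(=O)O)c1ccc2c(ccn2Cc2cccc(C)c2)c1`: 250 nM
- Compound 3, `C/C(=C\C(=O)Nc1ccccc1OCCCC(=O)O)c1ccc2c(ccn2Cc2ccc(C)cc2)c1`: 88 nM

Among these three, compound 3 stands in the middle: its number lies below that of compound 2 a 2.8-fold lower number from compound 2 to compound 3 (0.45 log units; beyond the scatter) and above that of compound 1 a 4.2-fold higher number from compound 1 to compound 3 (0.62 log units; beyond the scatter). Compound 1 also sits well apart from compound 2 a 12-fold higher number from compound 1 to compound 2 (1.08 log units; beyond the scatter).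

Compound 4, `C/C(=C\C(=O)Nc1ccccc1OCCCC(=O)O)c1ccc2c(ccn2Cc2ccc(C(C)(C)C)cc2)c1`, is not yet measured. It differs from compound 3 in one place: tert-butyl in place of methyl on an aromatic carbon.

For the measured compounds named here, none of the measured steps covers this exact change. The step between compound 2 and compound 3 concerns where a methyl sits on the benzyl ring, not its size. The steps from compound 1 show that the largest group on the aromatic nitrogen gives the lowest number, which hints that a bulkier group at this end may be tolerated, though this rests on a single compound. The expected outcome for compound 4 is therefore a modest lowering of the number, a 1.8-fold lower number from compound 3 to compound 4 (0.25 log units; within the scatter), with wide uncertainty.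

Compound 4 is estimated at 50 nM, within a range of 15 nM to 170 nM.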

Compound 4, half-maximal inhibitory concentration: 170 nM
Compound 4: middle estimate off by 3.4-fold (0.53 log units), on the low side; low and high end bracket the measured number.
By their numbers in this assay, from the lowest: compound 1; then compounds 3, 4 and 2 (each within the scatter of the next, the first and the last beyond it).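

In this assay, replacing methyl with tert-butyl on this aromatic carbon of the benzyl ring, which raises the group from 1 to 4 heavy atoms, gives a difference that stays within the usual scatter: a 1.9-fold higher number from compound 3 to compound 4 (0.29 log units; within the scatter). The new compound also cannot be separated from its 3-methylbenzyl relative, a 1.5-fold lower number from compound 2 to compound 4 (0.17 log units; within the scatter), yet a clear gap remains to the 1-butylpentyl compound, an 8.1-fold higher number from compound 1 to compound 4 (0.91 log units; beyond the scatter), so tert-butyl on the benzyl ring does not close that gap. Nothing available explains these numbers.

Going by these compounds, whether a chlorine, a methoxy group or a carboxylic acid on the same ring carbon would shift the number stays open. So does whether an unbranched pentyl chain on the aromatic nitrogen would match the 1-butylpentyl group.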